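Trimming a Second Methoxy from the Aryl Amine

A few compounds are considered here, and "the series" means these few. Any claim that something is new, unique, unknown or untested is made for them only; others in the source may bear on it.

In a functional assay on M14 cells (Homo sapiens) for inhibition, read by sulforhodamine B assay, with a stated time of 48 h (a lower number here means that less compound is tolerated, a higher number that more compound is tolerated), compound 3 `COc1ccc(CNc2nc3cc(N)cc(N)c3nc2-c2ccccc2)cc1OC` gives 33900 nM, the lowest of the two numbers shown. Its nearest neighbour is compound 2 `COc1cc(CNc2nc3cc(N)cc(N)c3nc2-c2ccccc2)cc(OC)c1OC`, which in this assay gives 34700 nM. Compound 1 `Nc1cc(N)c2nc(-c3ccccc3)c(Oc3ccc(Cl)c(Cl)c3)nc2c1` returns only a limit in this assay, < 100000 nM. For the measured compounds named here, the one measured step, a 1.0-fold lower number from compound 2 to compound 3 (0.01 log units; within the scatter), shows that removing a methoxy left the number within the scatter. The change to compound 4 `COc1ccc(CNc2nc3cc(N)cc(N)c3nc2-c2ccccc2)cc1` is of the same kind: hydrogen in place of methoxy on an aromatic carbon. Going by the values given here, with that single step as the only guide, the move from compound 3 to compound 4 is expected to give no change beyond the scatter, a 1.0-fold higher number from compound 3 to compound 4 (0.01 log units; within the scatter). Compound 4 is therefore estimated to give 35000 nM in this assay, with a range from 15000 nM to 85000 nM.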

Compound 4, concentration lethal to 50% of the cells: 57500 nM
Compound 4: the middle estimate sits 1.6-fold (0.22 log units) below what was measured, within the range that was stated.
By their numbers in this assay, from the lowest: compounds 3, 2 and 4 (each within the scatter of the next).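

Hydrogen in place of methoxy on an aromatic carbon, here turning 3,4-dimethoxyphenyl into 4-methoxyphenyl, again stays inside the noise in this assay: a 1.7-fold higher number from compound 3 to compound 4 (0.23 log units; within the scatter). A second example of this change thus joins the first, and at this place, ortho to a methoxy group, the methoxy can give way to hydrogen without a step beyond the scatter. Nothing shown here gives a cause for this step.

The compounds shown leave open what happens when the remaining methoxy goes as well. They also leave open whether an amine, a carboxylic acid or a longer chain at this place would move the number beyond the scatter.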